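Ester chain for phenoxy: a note on compound 3

The source may report more compounds than this note shows. Statements on the series, on what has been measured and on what is new or still open speak of the compounds shown alone.

In a functional assay for agonist activity at G protein-coupled receptor 88 (Homo sapiens), read by HTRF and cAMP accumulation (a lower number here means that less compound is needed, a higher number that more compound is needed for the effect), compound 2 `CC[C@H](C)[C@H](N)CN(C(=O)[C@@H]1C[C@H]1c1ccccc1)c1ccc(-c2ccc(Oc3ccccc3)cc2)cc1` gives 94 nM, a lower number than either entry of compound 1 `CC[C@H](C)[C@H](N)CN(C(=O)[C@@H]1C[C@H]1c1ccccc1)c1ccc(-c2ccccc2)cc1`, which gives 230 nM; 800 nM (2 entries); the spread of those repeats, (the several entries of compound 1 in this assay, 230 nM; 800 nM (2 entries)), shows how far single numbers move here. Among the measured compounds shown here, no step between measured compounds is available. Compound 3 `CC[C@H](C)[C@H](N)CN(C(=O)[C@@H]1C[C@H]1c1ccccc1)c1ccc(-c2ccc(CCC(=O)OC)cc2)cc1` differs from compound 2 by 2-(methoxycarbonyl)ethyl in place of phenoxy on an aromatic carbon. The step from compound 2 to compound 3 is expected to be a modest loss, a 2.1-fold higher number from compound 2 to compound 3 (0.33 log units; beyond the scatter), possibly still within the scatter. Compound 3 is estimated at 200 nM, between 60 nM and 700 nM.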

Compound 3, half-maximal effective concentration: 110 nM
Estimate against measurement, compound 3: 1.8-fold (0.26 log units) above; the range from low to high includes it.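

The ring of phenoxy is not required at this position in this assay: the open-chain 2-(methoxycarbonyl)ethyl takes its place on the aromatic carbon, with a 1.2-fold higher number from compound 2 to compound 3 (0.07 log units; within the scatter). The two groups therefore cannot be told apart here, and a single pair says little more, as single numbers in this series move widely: the several entries of compound 1 in this assay, 230 nM; 800 nM (2 entries).

From the compounds shown here alone, whether the ester carbonyl or the chain alone carries this result remains open. Going by these compounds, how a carboxylic acid or a longer chain would read at this position also remains open.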